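Trading a sulfonamide for an acetamide on the aromatic ring

This account rests on a few compounds, and the source may have more. Where it says the series, first, only, none or still open, it means among the compounds named here.

Among the measured compounds shown here, compound 3 `CNc1nc(NCc2ccc(NS(C)(=O)=O)cc2)cc(-c2ccccn2)n1` gives 3 nM in a functional assay on HEK293 cells for agonist activity at G-protein coupled receptor 39 (Homo sapiens), read by inositol phosphate accumulation (on this read-out higher numbers stand for an effect only at larger amounts of compound and lower numbers for an effect already at smaller amounts), the lowest of the three numbers measured so far. Compound 2 `CNC(=O)c1ccc(CNc2cc(-c3ccccn3)nc(NC)n2)cc1` gives 30 nM in this assay, and compound 1 `CNc1nc(NCc2ccc(S(C)(=O)=O)cc2)cc(-c2ccccn2)n1` gives 36 nM. The steps of a 10-fold lower number from compound 2 to compound 3 (1.00 log units; beyond the scatter) and a 12-fold lower number from compound 1 to compound 3 (1.08 log units; beyond the scatter) both lie beyond the scatter, whereas a 1.2-fold lower number from compound 1 to compound 2 (0.08 log units; within the scatter) does not: the group at this position matters, and the methanesulfonamido group stands out.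

Compound 4 `CNc1nc(NCc2ccc(N(C)C(C)=O)cc2)cc(-c2ccccn2)n1` carries the next variation at the same place: acetyl(methyl)amino in place of methanesulfonamido on an aromatic carbon. The group that leaves has the single hydrogen-bond donor of the three variants examined, and the new group has none. The two measured steps into compound 3 were both large and in the same direction, so undoing that group is expected to cost most of the gain, a step of roughly an 8.3-fold higher number from compound 3 to compound 4 (0.92 log units; beyond the scatter) back toward the numbers of compound 1 and compound 2. The estimated value for compound 4 in this assay is 25 nM, with a likely range from 6 nM to 100 nM.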

Compound 4, half-maximal effective concentration: 1180 nM
Compound 4: the middle estimate sits 47-fold (1.67 log units) below what was measured, outside the stated range (above it).
By their numbers in this assay, from the lowest: compound 3; then compounds 2 and 1 (each within the scatter of the next); then compound 4.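

Among the compounds shown here, compound 4 does not return to the level of the earlier compounds but goes far past it: in this assay the change gives a 390-fold higher number from compound 3 to compound 4 (2.59 log units; beyond the scatter), alongside a 39-fold higher number from compound 2 to compound 4 (1.59 log units; beyond the scatter) and a 33-fold higher number from compound 1 to compound 4 (1.52 log units; beyond the scatter). This position therefore does more than favour the methanesulfonamido group, as one replacement here can also push the number far above those of the methylsulfonyl and methylcarbamoyl compounds. The change also alters more than one feature at once, since the sulfonyl unit becomes a carbonyl and the hydrogen on the nitrogen becomes a methyl group.

Nothing available explains the size of this step. The compounds shown leave open which feature matters more, a question that a plain acetamido group or an N-methyl methanesulfonamido group at the same place could help separate.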